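This account rests on a few compounds, and the source may have more. Where it says the series, first, only, none or still open, it means among the compounds named here.

Compound 3 `Nc1scc(CN2CCN(c3c(F)cc(F)cc3F)CC2)c1C(=O)c1ccc(Cl)cc1` in a functional assay on CHO cells with adenosine receptor A1 (Homo sapiens) as the target, read by cAMP accumulation and immunoassay, with a stated time of 6 min, tested at 0.01 uM (on this read-out lower numbers stand for a stronger effect and higher numbers for a weaker effect at the one concentration tested), gives 4.2%. Compound 1 `Nc1scc(CN2CCN(c3ccncc3)CC2)c1C(=O)c1ccc(Cl)cc1` gives -4% and compound 2 `Nc1scc(CN2CCN(c3cccc4ccccc34)CC2)c1C(=O)c1ccc(Cl)cc1` gives 8.7%; compound 3 thus holds the second highest of the three numbers, but its gaps to both neighbours lie within the scatter, so no order among the three is claimed. Compound 4 `Nc1scc(CN2CCN(c3ccccc3Cl)CC2)c1C(=O)c1ccc(Cl)cc1` carries 2-chlorophenyl in place of 2,4,6-trifluorophenyl on an amine nitrogen in a ring. The measured steps that exchange the same group on the amine nitrogen in the ring are a number 12.7 percentage points higher from compound 1 to compound 2 (beyond the scatter), a number 8.2 percentage points higher from compound 1 to compound 3 (within the scatter) and a number 4.5 percentage points lower from compound 2 to compound 3 (within the scatter); only the first exceeds the scatter, and every aryl group tried so far leaves the read-out near zero at this concentration. For compound 4 a step of a number 0.8 percentage points higher from compound 3 to compound 4 (within the scatter) is expected, that is no change beyond the scatter in either direction. Compound 4 is therefore estimated at 5%, with a range from -8% to 18%.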

Compound 4, a percentage reported as activity, at one concentration (the size of the read-out at that concentration, not a potency): -2.1%
Compound 4: middle estimate off by 7.1 percentage points, on the high side; low and high end bracket the measured number.
By their numbers in this assay, from the lowest: compounds 1, 4, 3 and 2 (each within the scatter of the next, the first and the last beyond it).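

In this assay the change to 2-chlorophenyl on the amine nitrogen in the ring gives a number 6.3 percentage points lower from compound 3 to compound 4 (within the scatter) and a number 1.9 percentage points higher from compound 1 to compound 4 (within the scatter) so this group cannot be separated from 2,4,6-trifluorophenyl or pyridin-4-yl at this position. The third step, a number 10.8 percentage points lower from compound 2 to compound 4 (beyond the scatter) is modest, and it makes compound 4 the second compound set apart from naphthalen-1-yl in compound 2, while compound 3 goes against any such split by staying within the scatter of compound 2. No measurement shown here accounts for these steps.

As far as these compounds go, it remains open whether a benzyl group or a longer alkyl chain on this nitrogen would move the read-out beyond the scatter of compound 4. Also open, from the compounds shown here alone, is whether the modest gap between compound 2 and compound 4 would hold at other concentrations.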